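A few compounds are considered here, and "the series" means these few. Any claim that something is new, unique, unknown or untested is made for them only; others in the source may bear on it.

Working notes on the series, read in a functional assay on HepG2 cells (Homo sapiens) for inhibition, read by MTT assay, with a stated time of 48 h; on this read-out higher numbers stand for weaker inhibition and lower numbers for stronger inhibition. Compound 1 (`CCOC(=O)C1=C(N/C=N/c2cccnc2Cl)Nc2[nH]nc(C)c2C1c1ccc(N(C)C)cc1`) gives 4890 nM, compound 2 (`CCOC(=O)C1=C(N/N=C(\C#N)C(N)=O)Nc2[nH]nc(C)c2C1c1ccc(N(C)C)cc1`) gives 48400 nM, and compound 3 (`CCOC(=O)C(=NNC1=C(C(=O)OCC)C(c2ccc(N(C)C)cc2)c2c(C)n[nH]c2N1)C(=O)OCC`) gives 80800 nM. Compound 2 holds the second highest of the three numbers, and its nearest step is a 1.7-fold higher number from compound 2 to compound 3 (0.22 log units; within the scatter).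

Compound 4 (`CCOC(=O)C1=C(N/C=N/c2ccc(C)cc2)Nc2[nH]nc(C)c2C1c1ccc(N(C)C)cc1`) has not yet been measured. The change to it is a group of 9 heavy atoms (8 carbon, 1 nitrogen; one six-membered aromatic ring of carbon only) in place of a group of 7 heavy atoms (3 carbon, 3 nitrogen, 1 oxygen; no ring), on an amine nitrogen. Among the measured compounds, only compound 1 has a ring in the group on that nitrogen, although its ring carries a hetero atom and the ring entering here is of carbon only.

For the measured compounds named here, two measured steps bear on this: a 9.9-fold higher number from compound 1 to compound 2 (1.00 log units; beyond the scatter) and a 17-fold higher number from compound 1 to compound 3 (1.22 log units; beyond the scatter). Both point to a lower number for compound 4, though this rests on compound 1 alone, at 4890 nM.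

The expected step in this assay is a 6.9-fold lower number from compound 2 to compound 4 (0.84 log units; beyond the scatter). For compound 4 the estimate is 7000 nM, with an expected range of 2500 nM to 20000 nM.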

Compound 4, half-maximal inhibitory concentration: 44400 nM
The estimate for compound 4 lay 6.3-fold (0.80 log units) below the measured number; the measured number lies above the stated range.
By their numbers in this assay, from the lowest: compound 1; then compounds 4, 2 and 3 (each within the scatter of the next).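

In this assay, a carbon-only aromatic ring on this amine nitrogen does not by itself separate compound 4 from the open-chain groups: the steps (a 1.1-fold lower number from compound 2 to compound 4 (0.04 log units; within the scatter)) and (a 1.8-fold lower number from compound 3 to compound 4 (0.26 log units; within the scatter)) both stay within the scatter. The ring's identity does matter, as 4-methylphenyl in place of 2-chloropyridin-3-yl on the double-bonded nitrogen gives (a 9.1-fold higher number from compound 1 to compound 4 (0.96 log units; beyond the scatter)), so the lower number of compound 1 belongs to that particular group and not to the presence of a ring. No measurement at hand accounts for this gap.

The compounds shown leave open whether the chlorine, the ring nitrogen or the loss of the methyl carries the step from compound 1 to compound 4. An unsubstituted pyridin-3-yl, a 2-chlorophenyl or an unsubstituted phenyl on the same nitrogen would separate these three.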